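The compounds below may be only part of what the source reports. "The series", "measured", "known", "first", "only" and "open" are said of these compounds alone.

Measured compounds in a functional assay on BXPC-3 cells (Homo sapiens) for inhibition, read by MTT assay, with a stated time of 72 h; on this read-out higher numbers stand for weaker inhibition and lower numbers for stronger inhibition:
compound 1 `O=C(Nc1cc(F)cc2cccnc12)c1cnccn1` — limit of the assay: > 10000 nM
compound 2 `O=C(Nc1cc(Cl)cc2cccnc12)c1cnccn1` — limit of the assay: > 10000 nM
compound 3 `CC(C)(C)OC(=O)NCCOc1cc(NC(=O)c2cnccn2)c2ncccc2c1` — 9170 nM

Among the measured compounds shown here, compound 3 stands as the only compound of the series with a number in this assay; the two other values are limits (the limit of > 10000 nM in this assay, at which 2 of the 3 values shown sit). The change of chloro in place of fluoro on an aromatic carbon, a step that the two limits leave unreadable from compound 1 to compound 2, gives no readable size. Compound 4 `NCCOc1cc(NC(=O)c2cnccn2)c2ncccc2c1` differs from compound 3 by hydrogen in place of tert-butoxycarbonyl on an amine nitrogen. No measured step touches the amine nitrogen or its tert-butoxycarbonyl group, so no step of the series bears on this change; the one step shown is unreadable. With nothing to support a shift in either direction, the expectation for compound 4 is a value close to that of compound 3, any step staying within the scatter, estimated as a 1.0-fold lower number from compound 3 to compound 4 (0.01 log units; within the scatter). Compound 4 is accordingly expected at about 9000 nM, with a range from 3000 nM to 30000 nM.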

Compound 4, half-maximal inhibitory concentration: > 10000 nM
Compound 4: only a limit was reported (the forecaster's own chance of this, stated with the estimate: 40%); middle value at least 1.1-fold (0.04 log units) from the limit.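

In this assay, among the compounds shown here, hydrogen in place of tert-butoxycarbonyl on the amine nitrogen gives the first step that can be read on this side chain: an at least 1.0-fold higher number from compound 3 to compound 4 (0.03 log units; that floor lies within the scatter). The step shows no gain in inhibition from the free 2-aminoethyl chain, and its floor does not establish a loss. The steps from compound 1 and compound 2 to compound 4 cannot be read, and compound 3 remains the only compound with a number: the limit of > 10000 nM in this assay, at which 3 of the 4 values shown sit.

Going by these compounds, the true size of the step stays open, since the value of compound 4 is only a limit. Also open, on these data alone, is whether a longer chain, a tertiary amine or a carboxylic acid at the end of the chain would bring a number within the range of this assay.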